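A few compounds are considered here, and "the series" means these few. Any claim that something is new, unique, unknown or untested is made for them only; others in the source may bear on it.

In a functional assay on KB cells (Homo sapiens) for cytotoxicity (on this read-out lower numbers stand for stronger inhibition and higher numbers for weaker inhibition), compound 3 `CS(=O)(=O)Oc1ccc2c(c1)C(=O)C=CC2=O` gives 11600 nM, the lowest of the three numbers. Compound 2 `CCOc1ccc2c(c1)C(=O)C=CC2=O` gives 21400 nM, and the change between them is a 1.8-fold lower number from compound 2 to compound 3 (0.27 log units; within the scatter); compound 1 `COc1ccc2c(c1)C(=O)C=CC2=O` gives 33900 nM, and here the change is a 2.9-fold lower number from compound 1 to compound 3 (0.47 log units; beyond the scatter). Compound 4 `O=C1C=CC(=O)c2cc(Oc3cccs3)ccc21` differs from compound 3 at the same oxygen: thiophen-2-yl in place of methylsulfonyl on an oxygen on an aromatic ring. Every measured step alters the group on that oxygen, and the remaining one, a 1.6-fold lower number from compound 1 to compound 2 (0.20 log units; within the scatter), is also small; none reaches more than a modest size. Among the measured compounds shown here, no measured compound carries a ring on that oxygen, so the direction of the new step cannot be read from them. Compound 4 is therefore expected to shift little, with a 1.2-fold lower number from compound 3 to compound 4 (0.06 log units; within the scatter), and its estimated value is 10000 nM within a range of 4000 nM to 30000 nM.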

Compound 4, half-maximal inhibitory concentration: 18300 nM
Compound 4: the middle estimate sits 1.8-fold (0.26 log units) below what was measured; measured number inside the range.
By their numbers in this assay, from the lowest: compounds 3, 4, 2 and 1 (each within the scatter of the next, the first and the last beyond it).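

In this assay, among the compounds shown here, an aromatic ring on this oxygen appears for the first time, and thiophen-2-yl stays within the scatter of all three earlier groups (a 1.6-fold higher number from compound 3 to compound 4 (0.20 log units; within the scatter)) (a 1.2-fold lower number from compound 2 to compound 4 (0.07 log units; within the scatter)) (a 1.9-fold lower number from compound 1 to compound 4 (0.27 log units; within the scatter)). The position therefore carries a five-membered aromatic ring as well as the open groups and methylsulfonyl, with no step beyond the scatter. Nothing available bears on why these numbers lie so close. From the compounds shown here alone, whether an amine, a carboxylic acid or a longer chain on that oxygen would move the number further remains open, as does whether a phenyl ring would match thiophen-2-yl.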